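Removing one methoxy from the aryl ring of compound 2

A few compounds are considered here, and "the series" means these few. Any claim that something is new, unique, unknown or untested is made for them only; others in the source may bear on it.

Measured so far:
compound 1 `COc1ccc(-c2cc(/C=C/C(=O)c3ccc(N)cc3)[nH]n2)cc1`: -10%
compound 2 `COc1cc(-c2cc(/C=C/C(=O)c3ccc(N)cc3)[nH]n2)cc(OC)c1OC`: -38%
compound 3 `COc1ccc(C(=O)/C=C/c2cc(-c3cc(OC)c(OC)c(OC)c3)n[nH]2)cc1OC`: -94%

All three were tested in a functional assay on HT-29 cells (Homo sapiens) for cytotoxicity, read by sulforhodamine B assay, with a stated time of 48 h, tested at 10 uM; a lower number here means a stronger effect, a higher number a weaker effect of the compound at the concentration tested. Compound 2 stands second highest of the three; the nearest number, that of compound 1, is higher and the furthest, that of compound 3, is lower, both beyond the scatter. Compound 4 `COc1ccc(-c2cc(/C=C/C(=O)c3ccc(N)cc3)[nH]n2)cc1OC` is not yet measured; it differs from compound 2 by hydrogen in place of methoxy on an aromatic carbon.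

Within the data shown here, the only measured step, a number 56 percentage points lower from compound 2 to compound 3 (beyond the scatter), concerns the ring on the carbonyl carbon, not the ring changed here, so it does not bear on the change. Compound 1 and compound 2 differ at two places, so their values give only a rough bracket. A moderate upward step is expected, a number 13 percentage points higher from compound 2 to compound 4 (beyond the scatter), landing between those two.

Compound 4 is estimated at -25%, within -45% to -5%.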

Compound 4, a percentage reported as activity, at one concentration (the size of the read-out at that concentration, not a potency): -19%
The estimate for compound 4 lay 6 percentage points below the measured number; the measured number falls inside the stated range.
By their numbers in this assay, from the lowest: compound 3; then compound 2; then compounds 4 and 1 (each within the scatter of the next).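

In this assay, the methoxy ortho to a methoxy group now has a step of its own: hydrogen in its place gives a number 19 percentage points higher from compound 2 to compound 4 (beyond the scatter), so the effect at this position is modest but readable. The further methoxy separating compound 1 from compound 4 does not register, with a number 9 percentage points lower from compound 1 to compound 4 (within the scatter). Nothing at hand explains either step.

Open, on these data alone, is whether a hydroxyl group or a fluorine atom at this position would behave like methoxy or like hydrogen. Also open, as far as these compounds go, is whether the same removal would count equally with the 3,4-dimethoxyphenyl of compound 3 on the carbonyl carbon.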